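Dropping One Chloro Group: Compound 1 to Compound 4

The source may report more compounds than this note shows. Statements on the series, on what has been measured and on what is new or still open speak of the compounds shown alone.

Among the compounds with values here, compound 1, `COc1cc2ccc(=O)oc2cc1OCC(=O)c1ccc(Cl)c(Cl)c1`, is one of three compounds measured in a functional assay on HUVEC cells (Homo sapiens) for inhibition, read by MTT assay, with a stated time of 24 h, tested at 10 uM; a higher number here means more inhibition of growth at the concentration tested, a lower number less inhibition of growth. In this assay compound 1 gives 0%. Compound 3, `COc1cc2ccc(=O)oc2cc1OCC(O)CN1CCCC1`, gives 0.5%, a number that differs from compound 1 by no more than the usual scatter. Compound 2, `COc1cc2ccc(=O)oc2cc1OCCCCBr`, gives 11.2%, which lies beyond that scatter above compound 1. Compound 4, `COc1cc2ccc(=O)oc2cc1OCC(=O)c1ccc(Cl)cc1`, has not been measured. It differs from compound 1 in one place: hydrogen in place of chloro on an aromatic carbon. Within the data shown here, no measured pair shows this change, so the step is an expectation only: the author expects a step no larger than the scatter, with no clear direction. The expected step is a number 3 percentage points higher from compound 1 to compound 4 (within the scatter). Compound 4 is expected to give 3%, within a range from 0% to 13%.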

Compound 4, percent growth inhibition at one concentration: 62.6%
Beside the measured number, compound 4's estimate is 59.6 percentage points below it, and the stated range ends below it.
By their numbers in this assay, from the lowest: compounds 1 and 3 (each within the scatter of the next); then compound 2; then compound 4.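

In this assay, hydrogen in place of chloro on this aromatic carbon, ortho to the remaining chloro group, gives a number 62.6 percentage points higher from compound 1 to compound 4 (beyond the scatter) and so turns a compound without measurable inhibition into the clearest inhibitor shown. The earlier compounds shown here gave no reading of this position, and this step shows that one chlorine atom here can decide the result. Nothing available explains the size of this step.

The compounds shown leave open whether a fluoro group, a methoxy group or an amine on this carbon would keep the higher number, and whether the remaining chloro group is needed at all.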